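Swapping the nitrogen substituent on the core of compound 1

A few compounds are considered here, and "the series" means these few. Any claim that something is new, unique, unknown or untested is made for them only; others in the source may bear on it.

Compound 1 `CCC(CC)n1c(-c2ccc(OCc3c(-c4c(Cl)cccc4Cl)noc3C(C)C)cc2F)nc2ccc(C(=O)O)cc21` stands second highest of the three numbers measured in an assay on Huh-7 cells for agonist activity at Bile acid receptor (Homo sapiens), read by a luciferase reporter (a lower number here means that less compound is needed, a higher number that more compound is needed for the effect), where compound 1 gives 1.3 nM. Its closest neighbour is compound 2 `CCC(CC)n1c(-c2ccc(OCc3c(-c4c(Cl)cccc4Cl)noc3C(C)C)cc2)nc2ccc(C(=O)O)cc21`, which in this assay gives 0.8 nM; the step of a 1.6-fold lower number from compound 1 to compound 2 (0.21 log units; within the scatter) is a swap of hydrogen for fluoro on an aromatic carbon. The furthest is compound 3 `CC(C)c1onc(-c2c(Cl)cccc2Cl)c1COc1ccc(-c2nc3cc(C(=O)O)ccc3n2C)cc1`, which carries only a methyl on the aromatic nitrogen of the shared core and gives 25.8 nM in this assay.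

Compound 4 `CC(C)c1onc(-c2c(Cl)cccc2Cl)c1COc1ccc(-c2nc3ccc(C(=O)O)cc3n2CC2CCCCC2)c(F)c1` differs from compound 1 in one place: cyclohexylmethyl in place of pentan-3-yl on an aromatic nitrogen. Going by the values given here, no measured step touches this position directly. What the values of compound 2 and compound 3 show is that the compound with the small methyl on that nitrogen sits far higher than the one with the pentan-3-yl, so a group of comparable or greater size, such as cyclohexylmethyl, is not expected to move the number much. Compound 4 is therefore expected to stay close to compound 1, with a step of a 1.2-fold higher number from compound 1 to compound 4 (0.06 log units; within the scatter) that lies within the usual scatter. The estimate for compound 4 in this assay is 1.5 nM, with a range from 0.5 nM to 5 nM.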

Compound 4, half-maximal effective concentration: 7.8 nM
For compound 4 the middle estimate is 5.2-fold (0.72 log units) below the measured one; measured number outside the range, above it.
By their numbers in this assay, from the lowest: compounds 2 and 1 (each within the scatter of the next); then compound 4; then compound 3.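

Going by these compounds alone, this is the first measured step at this aromatic nitrogen, and it shows that the position still responds to a change between two groups that are both much larger than a methyl: in this assay the exchange of pentan-3-yl for cyclohexylmethyl gives a 6.0-fold higher number from compound 1 to compound 4 (0.78 log units; beyond the scatter). The change adds carbon and a six-membered non-aromatic ring, while the count of hydrogen-bond donors and acceptors and the net charge stay the same, so the difference in the number appears without any change in those counted features. Nothing available bears on the reason for this difference.

A single step cannot separate the effect of the ring from that of the added carbons or of the loss of the pentan-3-yl shape, and a straight pentyl chain or a cyclohexyl ring set directly on the nitrogen would be needed to pull these apart. Going by these compounds, it also remains open whether the step would keep its size with hydrogen in place of the fluoro, or whether an amine or an ether within the nitrogen substituent would be tolerated.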